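Pyrazole-core reductase inhibitors: amide substitution series

The source may hold more compounds than are shown below. What is called first, only, known or untested is meant among the compounds shown, and "the series" means these compounds.

Measured so far in an assay on microsomes from liver for inhibition of 3-hydroxy-3-methylglutaryl-coenzyme A reductase (Rattus norvegicus); on this read-out lower numbers stand for stronger inhibition and higher numbers for weaker inhibition:
compound 1 `CC(C)c1c(C(=O)NCc2cccc(F)c2F)nn(-c2ccc(F)cc2)c1OC[C@@H](O)C[C@@H](O)CC(=O)O`: 2 nM
compound 2 `Cc1ccccc1CNC(=O)c1nn(-c2ccc(F)cc2)c(OC[C@@H](O)C[C@@H](O)CC(=O)O)c1C(C)C`: 17 nM
compound 3 `COc1ccccc1CNC(=O)c1nn(-c2ccc(F)cc2)c(OC[C@@H](O)C[C@@H](O)CC(=O)O)c1C(C)C`: 22 nM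

Compound 3 gives the highest number of the three. Its gap to compound 2 lies within the scatter, so the two cannot be ordered, while an 11-fold higher number from compound 1 to compound 3 (1.04 log units; beyond the scatter) and an 8.5-fold higher number from compound 1 to compound 2 (0.93 log units; beyond the scatter) both lie beyond it, with compound 1 giving the lowest number of the set.

Compound 4 `COc1cccc(CN(C)C(=O)c2nn(-c3ccc(F)cc3)c(OC[C@@H](O)C[C@@H](O)CC(=O)O)c2C(C)C)c1` differs from compound 3 in one place: (3-methoxybenzyl)(methyl)amino in place of (2-methoxybenzyl)amino on a carbonyl carbon. Among the compounds with values here, no measured step touches either the amide nitrogen or the position of the methoxy on the ring. Within the data shown here, the only related step, a 1.3-fold higher number from compound 2 to compound 3 (0.11 log units; within the scatter), swaps one ring substituent for another and stays within the scatter, so it gives little guidance. The two aryl swaps starting from compound 1, an 8.5-fold higher number from compound 1 to compound 2 (0.93 log units; beyond the scatter) and an 11-fold higher number from compound 1 to compound 3 (1.04 log units; beyond the scatter), show that changes at this end of the molecule can move the number beyond the scatter.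

Among the measured compounds shown here, with no direct precedent, a modestly higher number is expected for compound 4, 60 nM, with a range of 15 nM to 250 nM; the expected step is a 2.7-fold higher number from compound 3 to compound 4 (0.44 log units; beyond the scatter).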

Compound 4, half-maximal inhibitory concentration: 21 nM
Beside the measured number, compound 4's estimate is 2.9-fold (0.46 log units) above it; low and high end bracket the measured number.
By their numbers in this assay, from the lowest: compound 1; then compounds 2, 4 and 3 (each within the scatter of the next).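

In this assay there is a 1.0-fold lower number from compound 3 to compound 4 (0.02 log units; within the scatter) when (3-methoxybenzyl)(methyl)amino replaces (2-methoxybenzyl)amino on the carbonyl carbon, so an amide lacking the amide hydrogen still gives a number in the same range. Alongside this stand a 1.2-fold higher number from compound 2 to compound 4 (0.09 log units; within the scatter) and an 11-fold higher number from compound 1 to compound 4 (1.02 log units; beyond the scatter) and so compound 4 falls with compounds 2 and 3, while compound 1 alone remains apart. Nothing measured on these compounds accounts for this result.

From the compounds shown here alone, the methyl on the amide nitrogen and the changed methoxy position arrive together in compound 4, so their separate contributions stay open; (3-methoxybenzyl)amino and (2-methoxybenzyl)(methyl)amino would divide them. Also open, going by these compounds, is whether the low number of compound 1 would hold with (2,3-difluorobenzyl)(methyl)amino, or with an ethyl group on that nitrogen.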